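Swapping the Aryl Group on the Hydrazone Nitrogen

The compounds below may be only part of what the source reports. "The series", "measured", "known", "first", "only" and "open" are said of these compounds alone.

Measured so far:
Compound 1, `Cc1cccc(C)c1NN=C1CCC(C)n2c1ncc(C(=O)O)c2=O`, gives 320 umol/kg.
Compound 2, `CC1CCC(=NNc2ccc(Br)cc2Cl)c2ncc(C(=O)O)c(=O)n21`, gives only a limit, > 100 umol/kg.

In a functional assay on the whole organism with Rattus norvegicus as the target (a higher number here means that more compound is needed for the effect, a lower number that less compound is needed), the picture is sparse. Compound 1 sits at a readable value. Compound 2 sits at the limit of > 100 umol/kg in this assay, at which 1 of the 2 values shown sits, which is a limit of the measurement and not a number. The step that the limit leaves unreadable from compound 1 to compound 2 is therefore unreadable, and compound 2 can only be placed at that limit.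

Compound 3, `Cc1cccc(Cl)c1NN=C1CCC(C)n2c1ncc(C(=O)O)c2=O`, differs from compound 2 by 2-chloro-6-methylphenyl in place of 4-bromo-2-chlorophenyl on an amine nitrogen. Among the compounds with values here, no measured step bears a readable size on this change, since the only step available ends at a limit. The entering 2-chloro-6-methylphenyl keeps a methyl as in the 2,6-dimethylphenyl of compound 1, so compound 3 is expected to land nearer compound 1 than at the limit. Compound 3 is therefore estimated at 250 umol/kg, with a range from 80 umol/kg to 800 umol/kg. That would correspond to an expected step that the limit leaves unreadable from compound 2 to compound 3.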

Compound 3, dose for 50% inhibition: > 100 umol/kg
Compound 3: no number, only a limit; the forecaster's own chance of this, stated with the estimate: 35%; the middle value lies beyond the limit too.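

In this assay compound 3 gives only a limit, > 100 umol/kg, not a number. Within the data shown here, no new step from compound 1 or compound 2 to compound 3 can be read. The compounds shown leave open how compound 2 and compound 3 compare with each other and with compound 1.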